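Aryl swaps on the triazole arm: compound 4 expected

This account rests on a few compounds, and the source may have more. Where it says the series, first, only, none or still open, it means among the compounds named here.

Compound 3 `O=c1ccoc2cc(OCc3cn(Cc4ccc([N+](=O)[O-])cc4)nn3)ccc12` gives 71300 nM in a functional assay on MDA-MB-231 cells (Homo sapiens) for cytotoxicity, read by MTT assay, with a stated time of 48 h (a lower number here means a stronger inhibitor, a higher number a weaker inhibitor), the highest of the two numbers shown; the nearest, compound 2 `O=c1ccoc2cc(OCc3cn(Cc4ccccc4Cl)nn3)ccc12`, gives 15100 nM, and there is a 4.7-fold higher number from compound 2 to compound 3 (0.67 log units; beyond the scatter). Compound 1 `O=c1ccoc2cc(OCc3cn(Cc4cccc([N+](=O)[O-])c4)nn3)ccc12` reaches only a limit, > 100000 nM; note (the limit of > 100000 nM in this assay, at which 1 of the 3 values shown sits). Compound 4 `N#Cc1cccc(Cn2cc(COc3ccc4c(=O)ccoc4c3)nn2)c1` differs from compound 3 by 3-cyanophenyl in place of 4-nitrophenyl on a saturated chain carbon bound to an aromatic nitrogen. Bearing on this are the aryl swaps already measured on that carbon: an at least 6.6-fold lower number from compound 1 to compound 2 (0.82 log units; beyond the scatter) and an at least 1.4-fold lower number from compound 1 to compound 3 (0.14 log units; that floor lies within the scatter), the latter within the scatter. Swaps among nitrophenyl groups and this cyanophenyl have so far stayed weak, so no step beyond the scatter is expected, a 1.1-fold higher number from compound 3 to compound 4 (0.05 log units; within the scatter). Compound 4 is estimated at 80000 nM, between 25000 nM and 250000 nM, with a real chance of a limit only.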

Compound 4, half-maximal inhibitory concentration: > 100000 nM
Compound 4 ended at the assay's limit; the forecaster's own chance of this, stated with the estimate: 40%; middle value at least 1.2-fold (0.09 log units) from the limit.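

With 3-nitrophenyl or 3-cyanophenyl on this saturated chain carbon, compound 1 and compound 4 both sit at a limit of this assay, not at a number: the limit of > 100000 nM in this assay, at which 2 of the 4 values shown sit.
The new 3-cyanophenyl group gives an at least 6.6-fold higher number from compound 2 to compound 4 (0.82 log units; beyond the scatter), a clear separation from 2-chlorophenyl, whereas an at least 1.4-fold higher number from compound 3 to compound 4 (0.14 log units; that floor lies within the scatter) leaves no readable separation from 4-nitrophenyl. The step with cyano in place of nitro cannot be read.

Open, going by these compounds, is how far any aryl group on this carbon can lower the number beyond compound 2. Also open, on these data alone, is what an amine or a carboxylic acid on the phenyl ring would give.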